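A few compounds are considered here, and "the series" means these few. Any claim that something is new, unique, unknown or untested is made for them only; others in the source may bear on it.

Measured compounds:
compound 1 `COc1cc2c(Oc3ccc(NC(=O)c4cc(-c5ccccc5)ccn4)cc3F)ccnc2cc1OCCCN1CCCC1` gives 120 nM
compound 2 `COc1cc2c(Oc3ccc(NC(=O)c4cc(-c5ccc(F)cc5)ccn4)cc3F)ccnc2cc1OCCCN1CCCC1` gives 430 nM
compound 3 `COc1cc2c(Oc3ccc(NC(=O)c4nccc(-c5ccc(F)cc5)n4)cc3F)ccnc2cc1OCCCN1CCCCC1` gives 120 nM

Of the compounds shown here, three have so far been tested in a functional assay on HT-29 cells (Homo sapiens) for cytotoxicity, read by MTT assay, with a stated time of 72 h; a lower number here means a stronger inhibitor, a higher number a weaker inhibitor. Compound 2 differs from compound 1 by fluoro in place of hydrogen on an aromatic carbon, and that change produced a 3.6-fold higher number from compound 1 to compound 2 (0.55 log units; beyond the scatter). Compound 3 stands level with compound 1 at the digits recorded; the difference between the cores of compound 1 and compound 3 is not broken down here, so the two can only be compared by their values, which are within the scatter of each other.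

Compound 4 `COc1cc2c(Oc3ccc(NC(=O)c4nccc(-c5ccc(F)cc5F)n4)cc3F)ccnc2cc1OCCCN1CCCCC1` has not yet been measured. It differs from compound 3 by fluoro in place of hydrogen on an aromatic carbon. For the measured compounds named here, this is the same kind of change as the one from compound 1 to compound 2, but not the same change: in compound 2 the fluoro sits para to a large group, whereas in compound 4 it sits ortho to a large group and meta to a fluoro group. Only one earlier instance of this kind of change exists among these compounds, so the expectation rests on that single step and on the different surroundings of the new fluoro. Because the earlier instance gave a 3.6-fold higher number from compound 1 to compound 2 (0.55 log units; beyond the scatter), a step of smaller size in the same direction is expected here, with the change of place leaving room for a smaller effect. Compound 4 is therefore expected to give 240 nM in this assay, estimated to lie between 100 nM and 600 nM. That estimate means an expected 2.0-fold higher number from compound 3 to compound 4 (0.30 log units; within the scatter).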

Compound 4, half-maximal inhibitory concentration: 400 nM
Beside the measured number, compound 4's estimate is 1.7-fold (0.22 log units) below it, within the range that was stated.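

In this assay, the change from 4-fluorophenyl to 2,4-difluorophenyl gave a 3.3-fold higher number from compound 3 to compound 4 (0.52 log units; beyond the scatter), and this step matches the earlier fluoro step in size and direction: the same change on two cores in this assay, a 3.6-fold higher number (0.55 log units; beyond the scatter) from compound 1 to compound 2 and a 3.3-fold higher number (0.52 log units; beyond the scatter) from compound 3 to compound 4, 1.1-fold (0.03 log units) apart, within the scatter of two such steps Within these two pairs, then, adding a fluoro to the outer aromatic ring carried over from one core to the other, and the number rose by a similar amount on both. This does not show that the place of the fluoro is irrelevant, as the new fluoro in compound 4 sits ortho to a large group and meta to a fluoro group, which is not where the fluoro of compound 2 sits, so core and place differ together across the two steps, and two steps are too few to support a rule for the series.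

The compounds shown leave open whether a fluoro at one and the same place would give a matching step on both cores. They also leave open whether a chloro, a methoxy or an amine in place of the new fluoro would move the number in the same direction as the two fluoro steps did.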